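This account rests on a few compounds, and the source may have more. Where it says the series, first, only, none or still open, it means among the compounds named here.

Measured so far:
compound 1 `CCCCN(c1nc2c(-c3nccn3C)cccc2o1)[C@H](C)c1ccc(-c2ccccc2-c2nnn[nH]2)cc1` gives 10 nM in a functional assay on CAL1 cells for inhibition of chemerin-like receptor 1 (Homo sapiens), with a stated time of 45 min; a higher number here means a weaker inhibitor, a lower number a stronger inhibitor
compound 2 `CCCCN(c1nc2c(C(=O)NS(C)(=O)=O)cccc2o1)[C@H](C)c1ccc(-c2ccccc2-c2nnn[nH]2)cc1` gives 14 nM in this assay

Going by the values given here, compound 2 holds the highest of the two numbers, but its only neighbour is compound 1, and the step of a 1.4-fold higher number from compound 1 to compound 2 (0.15 log units; within the scatter) lies within the scatter, so the two cannot be ordered. That single step replaced 1-methyl-1H-imidazol-2-yl on an aromatic carbon of the shared core by (methylsulfonyl)carbamoyl without a shift beyond the scatter.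

Compound 3 `CCCCN(c1nc2c(C(=O)N(C)C)cccc2o1)[C@H](C)c1ccc(-c2ccccc2-c2nnn[nH]2)cc1` has not been measured in this assay. Relative to compound 2 the change is dimethylamino in place of methanesulfonamido on a carbonyl carbon; read one bond further out, (methylsulfonyl)carbamoyl becomes dimethylcarbamoyl. Among the compounds with values here, the only measured step that bears on this site is a 1.4-fold higher number from compound 1 to compound 2 (0.15 log units; within the scatter), which shows the site tolerating an exchange of the whole substituent with no effect beyond the scatter. Within the data shown here, no measured pair separates the carbamoyl part from what hangs on it, so the expectation rests on that one step alone.

On this basis compound 3 is expected to stay within the scatter of compound 2, with an estimated step of a 1.4-fold higher number from compound 2 to compound 3 (0.15 log units; within the scatter) in this assay. Compound 3 is estimated at 20 nM, with a range from 6 nM to 70 nM.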

Compound 3, half-maximal inhibitory concentration: 13 nM
Estimate against measurement, compound 3: 1.5-fold (0.19 log units) above; the range from low to high includes it.
By their numbers in this assay, from the lowest: compounds 1, 3 and 2 (each within the scatter of the next).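

In this assay, dimethylamino in place of methanesulfonamido on a carbonyl carbon gives a 1.1-fold lower number from compound 2 to compound 3 (0.03 log units; within the scatter). Going by these compounds alone, this is the first pair that keeps the carbonyl and varies only what hangs on it, and it shows that the site accepts the exchange of a sulfur-bearing group with a hydrogen-bond donor and acceptors for dimethylamino, which has neither, without a shift beyond the scatter. The exchange of the whole substituent, dimethylcarbamoyl in place of 1-methyl-1H-imidazol-2-yl on an aromatic carbon, gives a 1.3-fold higher number from compound 1 to compound 3 (0.11 log units; within the scatter), so all three substituents now lie within the scatter of one another and cannot be ordered, and no data are available to account for this tolerance.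

Within the data shown here, since no step at this site has yet left the scatter, the limits of that tolerance remain unknown: a carboxylic acid, a primary amine or bare hydrogen on the same aromatic carbon could show whether any group there matters. The three compounds also share everything outside this site, so they say nothing about how the rest of the shared core contributes.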